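The source may report more compounds than this note shows. Statements on the series, on what has been measured and on what is new or still open speak of the compounds shown alone.

The measured compounds:

Compound 1 `CC(C)CCOc1ccccc1C1CC(=O)c2ccccc2O1`: 43.6%
Compound 2 `CCCOc1ccccc1C1CC(=O)c2ccccc2O1`: 43.6%
Compound 3 `O=C1CC(c2ccccc2OCc2cccc(F)c2)Oc2ccccc21`: 92.7%

In a functional assay on J774.A1 cells (Mus musculus) for inhibition, read by immunoassay, with a stated time of 12 h, tested at 30 uM (on this read-out lower numbers stand for less inhibition and higher numbers for more inhibition at the one concentration tested (going by the name of the read-out)), compound 3 stands highest of the three numbers. Its nearest neighbour is compound 1, with a number 49.1 percentage points higher from compound 1 to compound 3 (beyond the scatter), and compound 2 lies equally far off, with a number 49.1 percentage points higher from compound 2 to compound 3 (beyond the scatter). Compound 1 and compound 2 themselves show no change at the digits printed from compound 1 to compound 2 (within the scatter).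

Compound 4 `CCOc1ccccc1C1CC(=O)c2ccccc2O1` has not yet been measured in this assay. It differs from compound 3 as follows: methyl in place of 3-fluorophenyl on a saturated chain carbon bound to an oxygen on an aromatic ring. Cut one bond further out, the same difference reads 3-fluorobenzyl to ethyl.

Among the compounds with values here, two measured steps bear on this change directly, both in the reverse direction: the move from isobutyl to 3-fluorophenyl, a number 49.1 percentage points higher from compound 1 to compound 3 (beyond the scatter), and the move from ethyl to 3-fluorophenyl, a number 49.1 percentage points higher from compound 2 to compound 3 (beyond the scatter). Each was large and beyond the scatter. Removing the 3-fluorophenyl again, in favour of methyl, is therefore expected to bring a large step downward in this assay. Since compound 1 and compound 2, which carry two different saturated chains at this place, sit at the same number, compound 4 is expected to land near them, at an estimated 42% within 25% to 60%, which amounts to an expected step of a number 50.7 percentage points lower from compound 3 to compound 4 (beyond the scatter).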

Compound 4, a percentage reported as inhibition, at one concentration (the size of the read-out at that concentration, not a potency): 27.7%
Beside the measured number, compound 4's estimate is 14.3 percentage points above it; measured number inside the range.
By their numbers in this assay, from the lowest: compound 4; then compounds 1 and 2 (each within the scatter of the next); then compound 3.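

In this assay, the saturated chains at this place no longer all read alike: hydrogen in place of methyl on a saturated chain carbon, two bonds along the chain from an oxygen on an aromatic ring, gives a number 15.9 percentage points lower from compound 2 to compound 4 (beyond the scatter) and hydrogen in place of isopropyl at that carbon gives a number 15.9 percentage points lower from compound 1 to compound 4 (beyond the scatter) as modest steps beyond the scatter. The agreement between compound 1 and compound 2 therefore does not extend to compound 4, so among these three chain compounds, the end of the chain can matter even though methyl and isopropyl there show no difference. Methyl in place of 3-fluorophenyl gives a number 65 percentage points lower from compound 3 to compound 4 (beyond the scatter) as a large step, and this is well above the two modest steps, which leaves compound 3 clearly apart from all three chain compounds.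

Going by these compounds, what an unsubstituted benzyl group or a chain ending in an amine would give at this place stays open, so the share of the fluorine in the large step cannot be told from these compounds. Nothing available here explains either the large step or the modest ones.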